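Replacing the ring-nitrogen carbamate of compound 2 with a benzyl group

This account rests on a few compounds, and the source may have more. Where it says the series, first, only, none or still open, it means among the compounds named here.

Compound 2, `Cc1ccc2c(NCc3ccc(NC(=O)C4CCN(C(=O)OC(C)(C)C)CC4)cc3)nc(N(C)C)nc2c1`, in a functional assay on SV5A8 cells (Homo sapiens) for cytotoxicity (on this read-out lower numbers stand for stronger inhibition and higher numbers for weaker inhibition), gives > 4820 nM, which is a limit of the assay rather than a number. Compound 1, `COc1ccc(CN2CCC(C(=O)Nc3ccc(CNc4nc(N(C)C)nc5cc(C)ccc45)cc3)CC2)cc1`, in this assay gives > 6180 nM, likewise only a limit. The step that the two limits leave unreadable from compound 1 to compound 2 therefore cannot be read in size or direction; its two ends rest on the limit of > 4820 nM in this assay, at which 1 of the 2 values shown sits, and (the limit of > 6180 nM in this assay, at which 1 of the 2 values shown sits). Compound 3, `Cc1ccc2c(NCc3ccc(NC(=O)C4CCN(Cc5ccccc5F)CC4)cc3)nc(N(C)C)nc2c1`, arises from compound 2 by 2-fluorobenzyl in place of tert-butoxycarbonyl on an amine nitrogen in a ring. Within the data shown here, no measured step in this assay gives a readable size that bears on this change. Compound 1 carries a different benzyl group on that ring nitrogen and reaches only the limit > 6180 nM. Compound 3 is therefore expected near 8000 nM, within 3000 nM to 25000 nM. The step that the limit leaves unreadable from compound 2 to compound 3 that this estimate implies is expected to stay unreadable, most likely ending in another limit.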

Compound 3, half-maximal inhibitory concentration: > 6670 nM
Compound 3: no number, only a limit; the forecaster's own chance of this, stated with the estimate: 70%; the middle value does not contradict the limit.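

In this assay compound 3 gives > 6670 nM as a limit of the assay, not a number. Among these compounds, no step among compound 1, compound 2 and compound 3 can be read in size or direction. The compounds shown leave open whether the groups on the ring nitrogen differ at all on this read-out.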